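From compound 2 to compound 3: swapping one fluorinated group

The source may hold more compounds than are shown below. What is called first, only, known or untested is meant among the compounds shown, and "the series" means these compounds.

In a functional assay on LNCaP cells (Homo sapiens) for antiproliferative activity, read by propidium iodide staining, with a stated time of 96 h (a lower number here means a stronger inhibitor, a higher number a weaker inhibitor), compound 1 (`CC(O)(CSc1ccc(S(F)(F)(F)(F)F)cc1)C(=O)Nc1ccc([N+](=O)[O-])cc1C(F)(F)F`) gives 10300 nM. Compound 2 (`CC(O)(CSc1cccc(S(F)(F)(F)(F)F)c1)C(=O)Nc1ccc(S(F)(F)(F)(F)F)cc1`) gives 25000 nM, the higher of the two numbers and a gap beyond the scatter, which makes it the weaker inhibitor of the pair. Compound 3 (`CC(O)(CSc1cccc(C(F)(F)F)c1)C(=O)Nc1ccc(S(F)(F)(F)(F)F)cc1`) differs from compound 2 in one place, on an aromatic carbon: a group of 4 heavy atoms (1 carbon, 3 fluorine; no ring) in place of a group of 6 heavy atoms (5 fluorine, 1 sulfur; no ring), on an aromatic carbon. Among the measured compounds shown here, no measured pair shows this change on its own, so only a small shift is expected in this assay, with a 1.3-fold lower number from compound 2 to compound 3 (0.10 log units; within the scatter) estimated to stay within the scatter. Compound 3 is estimated at 20000 nM, with an expected range of 9000 nM to 45000 nM.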

Compound 3, half-maximal inhibitory concentration: 18300 nM
Estimate against measurement, compound 3: 1.1-fold (0.04 log units) above, and the stated range covers the measured number.
By their numbers in this assay, from the lowest: compounds 1, 3 and 2 (each within the scatter of the next, the first and the last beyond it).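

In this assay, among the compounds shown here, the trifluoromethyl group takes the place of the group of 6 heavy atoms (5 fluorine, 1 sulfur) on this aromatic carbon, meta to a large group, and the result is the first one-place step (a 1.4-fold lower number from compound 2 to compound 3 (0.14 log units; within the scatter)). At this position the read-out therefore does not separate the two fluorinated groups. Nothing measured here bears on why that is so.

Going by these compounds, whether an amine or a carboxylic acid on this aromatic carbon would shift the number beyond the scatter remains open. So does whether the same swap would behave alike on the other aromatic ring of the shared core.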